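Acetyl in Place of Hydrogen: Expected Cytotoxicity of Compound 3

This account rests on a few compounds, and the source may have more. Where it says the series, first, only, none or still open, it means among the compounds named here.

Of the compounds shown here, two sharing one core have been measured. Compound 1 `CCC[C@@H](OC(C)=O)C1=C(Br)/C(=C/Br)OC1=O` carries an acetyl on its side-chain oxygen and two bromines; in a functional assay on ZR-75-1 cells (Homo sapiens) for cytotoxicity (on this read-out higher numbers stand for an effect only at larger amounts of compound and lower numbers for an effect already at smaller amounts), compound 1 gives 1.6 ug/mL. Compound 2 `CCC[C@@H](O)C1=C(Br)/C(=C/I)OC1=O` carries a free hydroxy and an iodine in place of one bromine; in this assay compound 2 gives 0.3 ug/mL, the lowest of the two numbers and beyond the scatter from compound 1. The two differ in two places, so their gap cannot be tied to either one.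

Compound 3 `CCC[C@@H](OC(C)=O)C1=C(Br)/C(=C/I)OC1=O` is the next step from compound 2: acetyl in place of hydrogen on an oxygen on a saturated carbon. Compound 1 and compound 2 do not isolate this change, so the direction rests on the acetyl-bearing compound 1 having the higher number. The step of a 2.7-fold higher number from compound 2 to compound 3 (0.43 log units; beyond the scatter) is expected to be a modest rise, near the edge of the scatter. Compound 3 is estimated at 0.8 ug/mL, within 0.3 ug/mL to 2.5 ug/mL.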

Compound 3, concentration for half-maximal effect: < 0.1 ug/mL
Compound 3 gave a limit, no number; the forecaster's own chance of this, stated with the estimate: 5%; middle value at least 8.0-fold (0.90 log units) away from the limit.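

In this assay compound 3 gives a limit of the assay and not a number: the limit of < 0.1 ug/mL in this assay, at which 1 of the 3 values shown sits. Replacing the free hydroxy with acetoxy on this oxygen gives an at least 3.0-fold lower number from compound 2 to compound 3 (0.47 log units; beyond the scatter), so within this pair the hydrogen of the hydroxy is not needed for the effect, and the acetyl does not weaken it. Among these compounds, with the acetoxy kept in place, iodo in place of bromo on the double-bonded chain carbon gives an at least 16-fold lower number from compound 1 to compound 3 (1.20 log units; beyond the scatter), the first view of this exchange on its own, and a large step towards an effect at smaller amounts.

From the compounds shown here alone, how far the true value of compound 3 lies past the limit stays open, and with it the full size of both steps. Going by these compounds, whether a benzoyl or a methyl in place of the acetyl on this oxygen would keep such a low number is also open.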